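Fluoro for tert-Butyl on a Weakly Active Core

The source may report more compounds than this note shows. Statements on the series, on what has been measured and on what is new or still open speak of the compounds shown alone.

Compound 1, `C=C1CN/C(=N/c2ccccc2)S1`: in a functional assay on MCF7 cells (Homo sapiens) for antiproliferative activity, read by MTT assay, with a stated time of 72 h (a higher number here means a weaker inhibitor, a lower number a stronger inhibitor), compound 1 gives > 100000 nM, a limit of the assay.
Compound 2, `COc1ccc(/C=C2\S/C(=N\c3ccc(C(C)(C)C)cc3)N(C)C2=O)cc1`: in this assay compound 2 gives > 100000 nM, again a limit.
Compound 3, `COc1ccc(/C=C2/CN(C)/C(=N/c3ccc(OC)cc3)S2)cc1`: in this assay compound 3 gives 8700 nM.

Compound 2 stands at the limit of > 100000 nM in this assay, at which 2 of the 3 values shown sit, so no number is known for it, only that it lies beyond what the assay reports. Compound 3, built on a different core, is the only one of the three with a number. Compound 4, `COc1ccc(/C=C2\S/C(=N\c3ccc(F)cc3)N(C)C2=O)cc1`, differs from compound 2 by fluoro in place of tert-butyl on an aromatic carbon. Going by the values given here, no two measured compounds differ in one place only, so the size that such a change brings in this assay has no measured precedent here, and the gap between compound 2 and compound 4 cannot be set against the scatter from compound 2 alone. Compound 4 is expected to sit near the same limit, with a step of a number no higher from compound 2 to compound 4 (the limit leaves the size open) expected to stay within the scatter. Compound 4 is estimated at 100000 nM, in the range 30000 nM to 300000 nM.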

Compound 4, half-maximal inhibitory concentration: 66500 nM
Compound 4: middle estimate off by 1.5-fold (0.18 log units), on the high side; the measured number falls inside the stated range.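

With fluoro in place of tert-butyl on an aromatic carbon, the core shared by compound 2 and compound 4 now has a real number in this assay: compound 4 gives 66500 nM. Going by these compounds alone, the change at this position comes as an at least 1.5-fold lower number from compound 2 to compound 4 (0.17 log units; that floor lies within the scatter), the first step that can be read at all, though only as a floor. Going by these compounds, its true size stays open because compound 2 stands at a limit of the assay: the limit of > 100000 nM in this assay, at which 2 of the 4 values shown sit.

The compounds shown do not tell how an amine or a carboxylic acid would read at this position on the ring. Compound 3 and compound 4 differ in more than one place, which leaves the contribution of the core unread.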